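The source may hold more compounds than are shown below. What is called first, only, known or untested is meant among the compounds shown, and "the series" means these compounds.

Measured so far:
compound 1, `C=CCCCn1c(Cc2cc(OC)c(OC)c(OC)c2)nc2c(N)nc(F)nc21`: 44700 nM
compound 2, `CC/C=C/Cn1c(Cc2cc(OC)c(OC)c(OC)c2)nc2c(N)ncnc21`: 46800 nM
compound 3, `CCCCn1c(Cc2cc(OC)c(OC)c(OC)c2Cl)nc2c(N)ncnc21`: 19100 nM

In a functional assay on MCF7 cells (Homo sapiens) for antiproliferative activity (on this read-out higher numbers stand for weaker inhibition and lower numbers for stronger inhibition), compound 2 gives 46800 nM, the highest of the three numbers. Compound 1 sits beside it within the scatter, so the two cannot be ordered. Compound 3 gives 19100 nM. Its gap to compound 2 lies outside the scatter, but no single-point comparison connects the two, so its number is noted only as it stands.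

Compound 4, `C=CCCn1c(Cc2cc(OC)c(OC)c(OC)c2)nc2c(N)ncnc21`, is not yet measured. It differs from compound 2 as follows: allyl in place of but-1-en-1-yl on a saturated chain carbon bound to an aromatic nitrogen. This trims the chain on the aromatic nitrogen by one carbon while keeping one double bond outside aromatic rings. Among the measured compounds shown here, nothing among the measured compounds isolates such a change, and the two chain variants seen so far, compound 1 and compound 2, sit within the scatter of each other. The expected step of a 1.2-fold lower number from compound 2 to compound 4 (0.09 log units; within the scatter) is therefore small, if anything a modest move toward a lower number, not clearly beyond the scatter. Compound 4 is estimated at 38000 nM, in a range from 15000 nM to 95000 nM.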

Compound 4, half-maximal inhibitory concentration: 40700 nM
Estimate against measurement, compound 4: 1.1-fold (0.03 log units) below, within the range that was stated.
By their numbers in this assay, from the lowest: compound 3; then compounds 4, 1 and 2 (each within the scatter of the next).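

In this assay, the series now has its first comparison that differs in one place, and it reads a 1.1-fold lower number from compound 2 to compound 4 (0.06 log units; within the scatter). On a saturated chain carbon bound to an aromatic nitrogen, allyl with 3 heavy atoms in place of but-1-en-1-yl with 4 therefore gives no change that can be told from the scatter, with one double bond outside aromatic rings present on both sides. No evidence bears on this step.

The compounds shown leave open whether a longer chain, a fully saturated chain, an amine or a carboxylic acid in place of allyl would move the number beyond the scatter. The steps linking compound 3 to the other compounds cannot be read, as it differs from each in more than one place.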